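Methoxy in place of dimethylamino at the assay limit

The source may report more compounds than this note shows. Statements on the series, on what has been measured and on what is new or still open speak of the compounds shown alone.

In an ADME assay on BJ cells (Homo sapiens) for cytotoxicity, with a stated time of 72 h (a higher number here means that more compound is needed for the effect, a lower number that less compound is needed), compound 2 `Cc1cc(NC(=O)Nc2cccc(N(C)C)c2)c2ccccc2n1` gives only a limit, > 25000 nM. Compound 1 `Cc1cc(NC(=O)Nc2cccc(C(F)(F)F)c2)c2ccccc2n1` also gives only a limit, > 25000 nM. Neither compound therefore has a number, and the evidence so far is the limit of > 25000 nM in this assay, at which 2 of the 2 values shown sit.

Compound 3 `COc1cccc(NC(=O)Nc2cc(C)nc3ccccc23)c1` keeps the shared core and carries methoxy in place of dimethylamino on an aromatic carbon, meta to a large group: methoxy in place of dimethylamino on an aromatic carbon. Among the measured compounds shown here, the one measured step that bears on this change also replaces a group on an aromatic carbon. That step, a step that the two limits leave unreadable from compound 1 to compound 2, has no readable size, so it offers no measured size to carry over. No shift beyond the usual scatter is expected in this assay, and a further limit is the likeliest result. The expected outcome is a number no higher from compound 2 to compound 3 (the limit leaves the size open). For compound 3 the estimate is 25000 nM, with an expected range of 12000 nM to 50000 nM.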

Compound 3, half-maximal effective concentration: 27000 nM
Compound 3: middle estimate off by 1.1-fold (0.03 log units), on the low side; low and high end bracket the measured number.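

Among the compounds shown here, compound 3 now has a number in this assay, but compound 1 and compound 2 remain limits, so no step from either of them to compound 3 can be read. The compounds shown leave open how the trifluoromethyl, dimethylamino and methoxy compounds truly compare, the evidence being: the limit of > 25000 nM in this assay, at which 2 of the 3 values shown sit.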